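A Difluorophenyl Swap at the Weak End of the Scale

The compounds below may be only part of what the source reports. "The series", "measured", "known", "first", "only" and "open" are said of these compounds alone.

In a functional assay on A549 cells (Homo sapiens) for cytotoxicity, read by MTT assay, with a stated time of 48 h (on this read-out higher numbers stand for weaker inhibition and lower numbers for stronger inhibition), compound 1 `COc1cc(-n2c(-c3ccc(Cl)cc3)cn(C(C)=O)c2=O)cc(OC)c1OC` gives > 50000 nM, which is a limit of the assay and not a number. For the measured compounds named here, compound 2 `COc1cc(-n2c(-c3ccc([N+](=O)[O-])cc3)cn(C(C)=O)c2=O)cc(OC)c1OC` gives 49600 nM, the only true number so far in this assay. Compound 3 `COc1cc(-n2c(-c3ccc(F)cc3F)cn(C(C)=O)c2=O)cc(OC)c1OC` differs from compound 2 by 2,4-difluorophenyl in place of 4-nitrophenyl on an aromatic carbon, with 2,4-difluorophenyl in place of 4-nitrophenyl on an aromatic carbon. Going by the values given here, one measured step touches that same group, nitro in place of chloro, and it reads a number no higher from compound 1 to compound 2 (the limit leaves the size open). On these data alone, the size of that step stays open, and the limit of > 50000 nM in this assay, at which 1 of the 2 values shown sits, marks how close this pair sits to the limit. No measured size therefore supports a change beyond the usual scatter, and none is expected. The expected step is a 1.1-fold lower number from compound 2 to compound 3 (0.04 log units; within the scatter). For compound 3 the estimated value is 45000 nM, with an expected range from 15000 nM to 90000 nM.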

Compound 3, half-maximal inhibitory concentration: 24100 nM
Compound 3: the middle estimate sits 1.9-fold (0.27 log units) above what was measured; measured number inside the range.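

In this assay, for the compounds shown here, 2,4-difluorophenyl in place of 4-nitrophenyl gives a 2.1-fold lower number from compound 2 to compound 3 (0.31 log units; beyond the scatter), the first step on this aromatic carbon whose size can be read. Set against 4-chlorophenyl, the same group gives an at least 2.0-fold lower number from compound 1 to compound 3 (0.31 log units; beyond the scatter), so at this position 2,4-difluorophenyl reads lower than both of the other groups shown. The value of compound 1 is a limit and not a number, so that second step has a lower bound but no fixed size: the limit of > 50000 nM in this assay, at which 1 of the 3 values shown sits.

The compounds shown do not tell which of the two fluorines carries the step. They also leave open what an amine or a carboxylic acid on this aromatic ring would do, or a longer chain in place of the ring.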